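Removing the Carboxypiperidine: Expected Effect on Liver-Cell Toxicity

The source may hold more compounds than are shown below. What is called first, only, known or untested is meant among the compounds shown, and "the series" means these compounds.

Three related amides have been tested in an ADME assay on HepG2 cells (Homo sapiens) for cytotoxicity, with a stated time of 72 h; a higher number here means that more compound is needed for the effect, a lower number that less compound is needed. Compound 1 `Cc1ccc(-c2nc3ccccc3o2)cc1NC(=O)c1cc([N+](=O)[O-])ccc1Cl` gives > 14000 nM, which is a limit of the assay rather than a number. Compound 2 `COc1ccc(-c2nc3ccccc3s2)cc1NC(=O)c1cc([N+](=O)[O-])ccc1Cl` gives > 25000 nM, again a limit. Compound 3 `Cc1ccc(-c2nc3ccccc3s2)cc1NC(=O)c1cc([N+](=O)[O-])c(N2CCC(C(=O)O)CC2)cc1Cl` gives > 25000 nM, also a limit. Compound 3 thus stands at the limit of > 25000 nM in this assay, at which 2 of the 3 values shown sit, and no compound shown so far has produced a measurable effect.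

Compound 4 `Cc1ccc(-c2nc3ccccc3s2)cc1NC(=O)c1cc([N+](=O)[O-])ccc1Cl` has not yet been measured. It differs from compound 3 in one place: hydrogen in place of 4-carboxypiperidin-1-yl on an aromatic carbon. Compound 3 shows no effect within its tested range. Compounds 1 and 2, which also lack the 4-carboxypiperidin-1-yl group, likewise show no effect within their tested ranges. No step beyond the usual scatter is therefore expected in this assay. The expected step is a step that the limit leaves unreadable from compound 3 to compound 4. Compound 4 is estimated to give about 30000 nM, with a range from 10000 nM to 100000 nM, and the assay would most likely again report only a limit.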

Compound 4, half-maximal effective concentration: > 14000 nM
Compound 4: only a limit was reported (the forecaster's own chance of this, stated with the estimate: 85%); the middle value does not contradict the limit.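

Among these compounds, compounds 1, 2, 3 and 4 all give only limits in this assay, so no step from compound 1, compound 2 or compound 3 to compound 4 can be read. Whether any of these compounds reaches a measurable effect, and at what concentration, stays open.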